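This account rests on a few compounds, and the source may have more. Where it says the series, first, only, none or still open, it means among the compounds named here.

The three measured compounds, with their values in an in vitro functional assay on cells for agonist activity at Bombesin receptor subtype-3 (Homo sapiens), read by luminescence and calcium flux; a lower number here means that less compound is needed, a higher number that more compound is needed for the effect:

compound 1, `Cc1ccccc1Cc1cnc(CCc2ccc(-c3ccccc3C(=O)O)cc2)[nH]1`: 127 nM
compound 2, `CC(C)(C)Cc1cnc(CCc2ccc(-c3ccccc3C(=O)O)cc2)[nH]1`: 106 nM
compound 3, `Cc1ccc(Cc2cnc(CCc3ccc(-c4ccccc4C(=O)O)cc3)[nH]2)cc1`: 2660 nM

Compound 3 stands highest of the three numbers in this assay. It was reached by a 21-fold higher number from compound 1 to compound 3 (1.32 log units; beyond the scatter) and by a 25-fold higher number from compound 2 to compound 3 (1.40 log units; beyond the scatter), both large steps in the same direction, and in both the 4-methylphenyl group entered on the saturated chain carbon bound to an aromatic carbon.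

Compound 4, `O=C(O)c1ccccc1-c1ccc(CCc2ncc(Cc3ccccc3)[nH]2)cc1`, differs from compound 3 by hydrogen in place of methyl on an aromatic carbon. Within the data shown here, no measured step removes a methyl from this ring, so the bearing of the two steps onto compound 3 is only indirect: they show that the 4-methylphenyl group goes with the high number, while 2-methylphenyl in compound 1 and tert-butyl in compound 2 go with far lower numbers. Whether the methyl alone carries that difference is not shown. Compound 4 is therefore expected to give a lower number than compound 3, by about a 3.0-fold lower number from compound 3 to compound 4 (0.47 log units; beyond the scatter), with wide uncertainty. The estimate for compound 4 in this assay is 900 nM, expected to fall between 250 nM and 3500 nM.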

Compound 4, half-maximal effective concentration: 205 nM
Estimate against measurement, compound 4: 4.4-fold (0.64 log units) above; measured number below the stated range.
By their numbers in this assay, from the lowest: compounds 2, 1 and 4 (each within the scatter of the next); then compound 3.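

In this assay, taking the methyl off the 4-methylphenyl group gives a 13-fold lower number from compound 3 to compound 4 (1.11 log units; beyond the scatter) and so shows that this single methyl, on an aromatic carbon para to a large group, accounts for the high number of compound 3. Compound 4 also lies level with the other two, with a 1.6-fold higher number from compound 1 to compound 4 (0.21 log units; within the scatter) and a 1.9-fold higher number from compound 2 to compound 4 (0.29 log units; within the scatter) both within the scatter, so phenyl, 2-methylphenyl and tert-butyl cannot be told apart here and only 4-methylphenyl stands out. Nothing shown explains why this methyl matters so much.

Going by these compounds, it remains open whether chlorine, methoxy or an ethyl group at this same place would also give a high number. On these data alone, it is equally open whether an amide in place of the carboxylic acid would keep the number of compound 4.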